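The source may report more compounds than this note shows. Statements on the series, on what has been measured and on what is new or still open speak of the compounds shown alone.

In a functional assay on MCF7 cells (Homo sapiens) for cytotoxicity, read by LDH release, with a stated time of 48 h (on this read-out lower numbers stand for stronger inhibition and higher numbers for weaker inhibition), compound 1 (`O=C(COc1c(F)cc(C(=O)c2ccc(F)cc2)cc1Cl)NNC(=O)c1ccc(=O)oc1`) gives 61100 nM, compound 2 (`Cn1cnc(C(=O)NNC(=O)COc2ccc(C(=O)c3ccccc3)cc2)c1`) gives 31600 nM and compound 3 (`Cn1cnc(C(=O)NNC(=O)COc2c(F)cc(C(=O)c3ccc(F)cc3)cc2Cl)c1`) gives 44600 nM. Compound 3 thus stands within the scatter of both compound 1 and compound 2. Compound 4 (`Cn1cnc(C(=O)NNC(=O)COc2c(F)cc(C(=O)c3ccc(Cl)cc3)cc2Cl)c1`) differs from compound 3 in one place: chloro in place of fluoro on an aromatic carbon. Within the data shown here, no measured step tests this exchange directly. Among the measured compounds shown here, the one measured step, a 1.4-fold lower number from compound 1 to compound 3 (0.14 log units; within the scatter), replaces a different and larger group on a carbonyl carbon, yet stays within the scatter. A step beyond the scatter is therefore not expected for this single-atom exchange. The expected step is a 1.1-fold lower number from compound 3 to compound 4 (0.05 log units; within the scatter). For compound 4, the estimated value is 40000 nM, with a range of 20000 nM to 80000 nM.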

Compound 4, half-maximal inhibitory concentration: 44400 nM
The estimate for compound 4 lay 1.1-fold (0.05 log units) below the measured number, and the stated range covers the measured number.
By their numbers in this assay, from the lowest: compounds 2, 4, 3 and 1 (each within the scatter of the next).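

Putting 4-chlorophenyl in place of 4-fluorophenyl gives a 1.0-fold lower number from compound 3 to compound 4 (0.00 log units; within the scatter) in this assay. Among these compounds, at this position, para to a large group, the read-out therefore does not separate chloro from fluoro, a direct test that the earlier compounds did not offer. Nothing available explains why these two compounds read alike.

As far as these compounds go, it remains open whether a group other than a halogen at this position, such as an amine, a methoxy group or a carboxylic acid, would shift the number beyond the scatter. The same goes for a larger atom such as bromine.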